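The compounds below may be only part of what the source reports. "The series", "measured", "known", "first", "only" and "open" are said of these compounds alone.

Compound 3 `Cc1cccc(Oc2ccc(N3CCC[C@H]3CC(=O)O)cc2)c1` is one of three aryl ethers sharing a core and differing only in the ring carried on the oxygen. In a functional assay on cells for agonist activity at Free fatty acid receptor 1 (Mus musculus), read by FLIPR and calcium flux, with a stated time of 100 s (a lower number here means that less compound is needed, a higher number that more compound is needed for the effect), compound 3 gives 2400 nM. Compound 1 `Cc1ccccc1Oc1ccc(N2CCC[C@H]2CC(=O)O)cc1` gives 5600 nM in this assay, and compound 2 `O=C(O)C[C@@H]1CCCN1c1ccc(Oc2ccc(Cl)cc2Cl)cc1` gives 3200 nM. The step of a 2.3-fold lower number from compound 1 to compound 3 (0.37 log units; beyond the scatter) is the only one in the set that clears the scatter, while a 1.3-fold lower number from compound 2 to compound 3 (0.12 log units; within the scatter) and a 1.8-fold lower number from compound 1 to compound 2 (0.24 log units; within the scatter) do not; compound 3 therefore sits at the low end of the numbers seen, separated from compound 1 but not from compound 2.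

Compound 4 `Cc1ccc(Oc2ccc(N3CCC[C@H]3CC(=O)O)cc2)cc1` differs from compound 3 by 4-methylphenyl in place of 3-methylphenyl on an oxygen on an aromatic ring. Within the data shown here, the one step that speaks to moving the methyl group around the ring, a 2.3-fold lower number from compound 1 to compound 3 (0.37 log units; beyond the scatter), was modest; the shift from 2,4-dichlorophenyl to 3-methylphenyl, a 1.3-fold lower number from compound 2 to compound 3 (0.12 log units; within the scatter), stayed within the scatter. The expected step of a 1.0-fold higher number from compound 3 to compound 4 (0.02 log units; within the scatter) is accordingly small, with no confident direction beyond the scatter. Compound 4 is estimated at 2500 nM in this assay, within a range of 1000 nM to 6000 nM.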

Compound 4, half-maximal effective concentration: > 33000 nM
Compound 4: only a limit was reported; the forecaster's own chance of this, stated with the estimate: 5%; middle value at least 13-fold (1.12 log units) from the limit.
By their numbers in this assay, from the lowest: compounds 3, 2 and 1 (each within the scatter of the next, the first and the last beyond it). At a limit, above all of these: compound 4.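

In this assay, moving the methyl group alone, with 4-methylphenyl in place of 3-methylphenyl on the same oxygen, gives an at least 13-fold higher number from compound 3 to compound 4 (1.13 log units; beyond the scatter), although the two groups have the same atoms. Among these compounds, the other two changes at this place point the same way, with an at least 10-fold higher number from compound 2 to compound 4 (1.01 log units; beyond the scatter) and an at least 5.8-fold higher number from compound 1 to compound 4 (0.77 log units; beyond the scatter), so 4-methylphenyl stands apart from the three earlier groups, among which no step was larger than modest. The value of compound 4 is a limit and not a number: the limit of > 33000 nM in this assay, at which 1 of the 4 values shown sits.

From the compounds shown here alone, how far compound 4 lies past that limit stays open. Also open, going by these compounds, is whether 4-chlorophenyl or 4-methoxyphenyl would fall with compound 4 or with compound 2, whose 2,4-dichlorophenyl goes against any reading that a group at the 4 position alone gives this result.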